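This account rests on a few compounds, and the source may have more. Where it says the series, first, only, none or still open, it means among the compounds named here.

In a functional assay on A549 cells (Homo sapiens) for cytotoxicity, read by MTT assay, with a stated time of 48 h (a higher number here means a weaker inhibitor, a lower number a stronger inhibitor), compound 1 (`CC1(C)CCC[C@]2(C)[C@@H](CC[C@@](C)(O)/C=C/c3cncc4ccccc34)[C@](C)(O)CC[C@@H]12`) gives 45700 nM, compound 2 (`COc1cccc(OC)c1/C=C/[C@](C)(O)CC[C@@H]1[C@@]2(C)CCCC(C)(C)[C@@H]2CC[C@@]1(C)O`) gives 42000 nM and compound 3 (`COc1cccc(/C=C/[C@](C)(O)CC[C@@H]2[C@@]3(C)CCCC(C)(C)[C@@H]3CC[C@@]2(C)O)c1OC`) gives 3280 nM. Compound 2 thus stands level with compound 1, and both lie well above compound 3. Compound 4 (`Cc1cccc(C)c1/C=C/[C@](C)(O)CC[C@@H]1[C@@]2(C)CCCC(C)(C)[C@@H]2CC[C@@]1(C)O`) carries 2,6-dimethylphenyl in place of 2,6-dimethoxyphenyl on a double-bonded chain carbon bound to a double-bonded chain carbon. For the measured compounds named here, two measured steps bear on this change: a 1.1-fold lower number from compound 1 to compound 2 (0.04 log units; within the scatter), within the scatter, and the large 13-fold lower number from compound 2 to compound 3 (1.11 log units; beyond the scatter), which brings in 2,3-dimethoxyphenyl. Neither exchanges dimethoxyphenyl for dimethylphenyl, so no shift beyond the scatter is expected in this assay. The expected change is a 1.2-fold lower number from compound 2 to compound 4 (0.08 log units; within the scatter). For compound 4 the estimated value is 35000 nM, with an expected range of 12000 nM to 80000 nM.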

Compound 4, half-maximal inhibitory concentration: 3340 nM
Estimate against measurement, compound 4: 10-fold (1.02 log units) above; measured number below the stated range.
By their numbers in this assay, from the lowest: compounds 3 and 4 (each within the scatter of the next); then compounds 2 and 1 (each within the scatter of the next).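

In this assay, 2,6-dimethylphenyl in place of 2,6-dimethoxyphenyl on a double-bonded chain carbon gives a 13-fold lower number from compound 2 to compound 4 (1.10 log units; beyond the scatter), so a large step at this place no longer depends on 2,3-dimethoxyphenyl. Against isoquinolin-4-yl the new group gives a 14-fold lower number from compound 1 to compound 4 (1.14 log units; beyond the scatter), and against 2,3-dimethoxyphenyl it gives a 1.0-fold higher number from compound 3 to compound 4 (0.01 log units; within the scatter), which puts these two groups level. No available evidence bears on why this exchange matters so much. On these data alone, whether unsubstituted phenyl or 2,6-dichlorophenyl at this place would stand with compound 3 and compound 4 or with compound 1 and compound 2 stays open.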